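A few compounds are considered here, and "the series" means these few. Any claim that something is new, unique, unknown or untested is made for them only; others in the source may bear on it.

Measured compounds:
Compound 1 `Cc1noc(C)c1-c1cnc(N)c(Oc2ccc(C(=O)Nc3ccc(Cl)cc3)cc2)n1` gives 15500 nM in a functional assay on U-87MG ATCC cells for inhibition, with U-87 MG (Homo sapiens) as the target, read by MTT assay, with a stated time of 72 h; on this read-out higher numbers stand for weaker inhibition and lower numbers for stronger inhibition.
Compound 2 `Cc1noc(C)c1-c1cnc(N)c(Oc2ccc(C(=O)Nc3cccc(Cl)n3)cc2)n1` gives 64100 nM in this assay.

Going by the values given here, compound 2 stands highest of these two numbers, that is, it shows the weaker inhibition; its only neighbour is compound 1, and the step of a 4.1-fold higher number from compound 1 to compound 2 (0.62 log units; beyond the scatter) lies beyond the scatter. Compound 3 `Cc1noc(C)c1-c1cnc(N)c(Oc2ccc(C(=O)Nc3cc(Cl)ccn3)cc2)n1` has not yet been measured. It differs from compound 2 in one place: 4-chloropyridin-2-yl in place of 6-chloropyridin-2-yl on an amide-type nitrogen. The two compounds have the same atoms, joined differently; the ring on the amide-type nitrogen keeps its chlorine, but as 4-chloropyridin-2-yl rather than 6-chloropyridin-2-yl.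

Among the compounds with values here, only one measured step exists, from compound 1 to compound 2, and it exchanges the whole ring on the amide-type nitrogen rather than moving a chlorine within a pyridinyl, so it does not directly cover this change. It does show that this part of the molecule can shift the number in this assay by a modest amount. Within the data shown here, with no step covering the change, compound 3 is expected to land near compound 2, with a wide range. Compound 3 is therefore estimated at about 50000 nM in this assay, between 15000 nM and 150000 nM. The expected step of a 1.3-fold lower number from compound 2 to compound 3 (0.11 log units; within the scatter) is estimated to stay within the scatter.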

Compound 3, half-maximal inhibitory concentration: 70800 nM
Beside the measured number, compound 3's estimate is 1.4-fold (0.15 log units) below it; low and high end bracket the measured number.
By their numbers in this assay, from the lowest: compound 1; then compounds 2 and 3 (each within the scatter of the next).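

Within the chloropyridinyl series, 4-chloropyridin-2-yl in place of 6-chloropyridin-2-yl on the amide-type nitrogen gives a 1.1-fold higher number from compound 2 to compound 3 (0.04 log units; within the scatter), so this assay does not tell these two arrangements of the same atoms apart. The second new comparison, 4-chloropyridin-2-yl in place of 4-chlorophenyl, gives a 4.6-fold higher number from compound 1 to compound 3 (0.66 log units; beyond the scatter), which lies beyond the scatter, as does a 4.1-fold higher number from compound 1 to compound 2 (0.62 log units; beyond the scatter); the gap from the 4-chlorophenyl compound is therefore not limited to 6-chloropyridin-2-yl, and both chloropyridinyl compounds show weaker inhibition than compound 1. Nothing measured alongside these numbers bears on what lies behind them.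

The compounds shown leave open what the chlorine itself contributes, since they do not tell how a pyridin-2-yl ring carrying a methyl or methoxy group in its place, or no group at all, would read in this assay. They also leave open whether a change elsewhere, such as a carboxylic acid or an amine on the phenyl ring of the amide, would shift the number more than the chlorine arrangement does.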